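From methoxy to methyl on compound 3

This account rests on a few compounds, and the source may have more. Where it says the series, first, only, none or still open, it means among the compounds named here.

Compound 1 `COc1ccc(-c2nnc(SCCCN3CCN(c4nc5ccccc5o4)CC3)o2)cc1` gives 52700 nM
Compound 2 `Cc1ccc(-c2nnc(SCCCN3CCN(c4nc5ccccc5o4)CC3)o2)cc1` gives 100000 nM
Compound 3 `COc1ccc(-c2nnc(SCCCN3CCN(c4nc5ccccc5s4)CC3)o2)cc1` gives 56200 nM
Compound 4 `Cc1ccc(-c2nnc(SCCCN3CCN(c4nc5ccccc5s4)CC3)o2)cc1` is not yet measured

In a functional assay on A-431 cells (Homo sapiens) for inhibition, read by MTT assay, with a stated time of 72 h (a higher number here means a weaker inhibitor, a lower number a stronger inhibitor), the three measured values lie within the usual scatter of one another, so compound 3 has no clear rank among them. Compound 4 differs from it by methyl in place of methoxy on an aromatic carbon and in nothing else. This same swap has been measured once, as a 1.9-fold higher number from compound 1 to compound 2 (0.28 log units; within the scatter) in the other core. The exchange of 1,3-benzoxazol-2-yl for 1,3-benzothiazol-2-yl was smaller, a 1.1-fold higher number from compound 1 to compound 3 (0.03 log units; within the scatter) so the swap should carry over. A similar rise in the number is therefore expected, and it may not clear the scatter. The estimated change is a 1.7-fold higher number from compound 3 to compound 4 (0.23 log units; within the scatter) in this pair. Compound 4 is expected at 95000 nM with an estimated range of 50000 nM to 180000 nM for its measurement.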

Compound 4, half-maximal inhibitory concentration: 61600 nM
Beside the measured number, compound 4's estimate is 1.5-fold (0.19 log units) above it, and the stated range covers the measured number.
By their numbers in this assay, from the lowest: compounds 1, 3, 4 and 2 (each within the scatter of the next).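

In this assay, the swap from 4-methoxyphenyl to 4-methylphenyl now has a second reading on a second core, a 1.1-fold higher number from compound 3 to compound 4 (0.04 log units; within the scatter), so on both cores this change stays within the scatter. The two readings also agree with each other within the scatter: the same change on two cores in this assay, a 1.9-fold higher number (0.28 log units; within the scatter) from compound 1 to compound 2 and a 1.1-fold higher number (0.04 log units; within the scatter) from compound 3 to compound 4, 1.7-fold (0.24 log units) apart, within the scatter of two such steps The exchange of 1,3-benzoxazol-2-yl for 1,3-benzothiazol-2-yl, now read in a second pair as a 1.6-fold lower number from compound 2 to compound 4 (0.21 log units; within the scatter), likewise stays within the scatter on both cores: the same change on two cores in this assay, a 1.1-fold higher number (0.03 log units; within the scatter) from compound 1 to compound 3 and a 1.6-fold lower number (0.21 log units; within the scatter) from compound 2 to compound 4, 1.7-fold (0.24 log units) apart, within the scatter of two such steps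

Going by these compounds, whether a different group on this aromatic carbon, such as an amine or a carboxylic acid, would move the number beyond the scatter remains open.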